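The source may hold more compounds than are shown below. What is called first, only, known or untested is meant among the compounds shown, and "the series" means these compounds.

For the measured compounds named here, in an assay on HEK-293T cells for inhibition of diacylglycerol lipase-alpha (Homo sapiens), read by colorimetric assay (on this read-out higher numbers stand for weaker inhibition and lower numbers for stronger inhibition), compound 2 `O=Cc1coc(C(=O)CCCCCCc2ccccc2)n1` gives 1510 nM, the second highest of the three numbers measured so far. Compound 1 `CC(C)(C)C(=O)c1coc(C(=O)CCCCCCc2ccccc2)n1` gives 479 nM and compound 3 `CN(C)C(=O)c1coc(C(=O)CCCCCCc2ccccc2)n1` gives 3390 nM; the corresponding steps are a 3.2-fold higher number from compound 1 to compound 2 (0.50 log units; beyond the scatter) and a 2.2-fold higher number from compound 2 to compound 3 (0.35 log units; beyond the scatter), with a 7.1-fold higher number from compound 1 to compound 3 (0.85 log units; beyond the scatter) spanning the whole set. Compound 4 `O=C(CCCCCCc1ccccc1)c1ncc(Cl)o1` differs from compound 2 in one place: 5-chloro-1,3-oxazol-2-yl in place of 4-formyl-1,3-oxazol-2-yl on a carbonyl carbon. Every measured step swaps one group on a carbonyl carbon while keeping the 4-formyl-1,3-oxazol-2-yl motif in place, and each of those swaps moved the number by a modest amount, always beyond the scatter. Going by the values given here, no measured step removes that carbonyl or introduces a chlorine on the ring, so the measured steps bear on the change only loosely. Because a 7.1-fold higher number from compound 1 to compound 3 (0.85 log units; beyond the scatter) and the other steps at this part of the molecule each gave a modest shift, a modest step toward a higher number is expected, a 1.7-fold higher number from compound 2 to compound 4 (0.22 log units; within the scatter). Compound 4 is therefore estimated at 2500 nM in this assay, with a range from 600 nM to 10000 nM.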

Compound 4, half-maximal inhibitory concentration: > 10000 nM
Compound 4: no number, only a limit; the forecaster's own chance of this, stated with the estimate: 10%; middle value at least 4.0-fold (0.60 log units) away from the limit.
By their numbers in this assay, from the lowest: compound 1; then compound 2; then compound 3. At a limit, above all of these: compound 4.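

In this assay compound 4 gives no number, only a limit: the limit of > 10000 nM in this assay, at which 1 of the 4 values shown sits. Putting 5-chloro-1,3-oxazol-2-yl in place of 4-formyl-1,3-oxazol-2-yl on the carbonyl carbon gives an at least 6.6-fold higher number from compound 2 to compound 4 (0.82 log units; beyond the scatter), and the full size of this step cannot be read from a limit. The earlier compounds differ only in the group on the other carbonyl and all stay within the measured range, from compound 1 at 479 nM to compound 3 at 3390 nM, whereas this change to the ring substituents is the only one shown that leaves that range.

Compound 4 loses the formyl-bearing group and gains a chlorine in a single change, and the compounds shown do not separate these two parts. Going by these compounds, how a plain 1,3-oxazol-2-yl group, or a methyl or nitrile in place of the chlorine, would behave remains open.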